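The source may hold more compounds than are shown below. What is called first, only, known or untested is meant among the compounds shown, and "the series" means these compounds.

In an ADME assay on BaF3 cells (Mus musculus) for antiproliferative activity, read by CCK-8 assay, with a stated time of 72 h (a higher number here means a weaker inhibitor of growth, a lower number a stronger inhibitor of growth), compound 1, `CNC(=O)CCSc1ccc2c(/C=C/c3ccccn3)n[nH]c2c1`, gives > 10000 nM, which is a limit of the assay and not a number. Compound 2, `Cc1cccc(NC(=O)CCSc2ccc3c(/C=C/c4ccccn4)n[nH]c3c2)c1`, gives > 10000 nM, which is again only a limit. Both readings therefore rest at the same ceiling: the limit of > 10000 nM in this assay, at which 2 of the 2 values shown sit. Among the measured compounds shown here, the one measured step, a step that the two limits leave unreadable from compound 1 to compound 2, places 3-methylphenyl where methyl stood on an amide-type nitrogen, and its size cannot be read.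

Compound 3, `O=C(CCSc1ccc2c(/C=C/c3ccccn3)n[nH]c2c1)Nc1cccc(C(F)(F)F)c1`, differs from compound 2 at a single place: trifluoromethyl in place of methyl on an aromatic carbon. This puts trifluoromethyl in place of methyl on an aromatic carbon, meta to a large group. The measured step offers no size or direction to carry over to this change, so no definite shift is expected in this assay. The best guide is compound 2 itself, whose reading is the limit > 10000 nM.

The expected step is small and uncertain: a number no higher from compound 2 to compound 3 (the limit leaves the size open). For compound 3 the estimate is 10000 nM, with an expected range from 3000 nM to 20000 nM, and a report of only the same limit is the likeliest outcome.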

Compound 3, concentration for 50% growth inhibition: 2300 nM
The estimate for compound 3 lay 4.3-fold (0.64 log units) above the measured number; the whole stated range lies above it.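

Trifluoromethyl in place of methyl on the aromatic carbon gives an at least 4.3-fold lower number from compound 2 to compound 3 (0.63 log units; beyond the scatter) in this assay, so the group at this place on the phenyl ring does affect the reading, something two readings at the ceiling could not show. 3-(Trifluoromethyl)phenyl in place of methyl on the amide-type nitrogen gives an at least 4.3-fold lower number from compound 1 to compound 3 (0.63 log units; beyond the scatter), while the step from methyl to 3-methylphenyl on that nitrogen cannot be read, which means the change at the nitrogen has a readable effect only when the phenyl ring carries trifluoromethyl. Compound 3 is the only one of the three with a measured number, and the other two stay at the ceiling: the limit of > 10000 nM in this assay, at which 2 of the 3 values shown sit.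

As far as these compounds go, the full size of both readable steps remains unknown, as the readings for compound 1 and compound 2 are limits and not numbers. Also open, from the compounds shown here alone, is whether a chlorine atom, a nitrile or a methoxy group at this same place, or trifluoromethyl on another carbon of the ring, would give a number of the same order.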